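The source may report more compounds than this note shows. Statements on the series, on what has been measured and on what is new or still open speak of the compounds shown alone.

Compound 1, `c1ccc2c(c1)CC2CCCN1CCN(c2cccc3c2OCCO3)CC1`: in a functional assay on the whole organism for agonist activity, with Rattus norvegicus as the target (on this read-out higher numbers stand for an effect only at larger amounts of compound and lower numbers for an effect already at smaller amounts), compound 1 gives 10 mg/kg.
Compound 2, `c1ccc2c(c1)CCC2CCN1CCN(c2cccc3c2OCCO3)CC1`: in this assay compound 2 gives > 40 mg/kg, which is a limit of the assay and not a number.

Compound 2 thus stands at the limit of > 40 mg/kg in this assay, at which 1 of the 2 values shown sits. Compound 3, `C1=C(CCN2CCN(c3cccc4c3OCCO4)CC2)Cc2ccccc21`, differs from compound 2 in one place: a group of 9 heavy atoms (9 carbon; one five-membered non-aromatic ring of carbon only, one six-membered aromatic ring of carbon only) in place of a group of 9 heavy atoms (9 carbon; one five-membered non-aromatic ring of carbon only, one six-membered aromatic ring of carbon only), on a saturated chain carbon, two bonds along the chain from an amine nitrogen in a ring. Among the measured compounds shown here, the only measured step, an at least 4.0-fold higher number from compound 1 to compound 2 (0.60 log units; beyond the scatter), concerns a change of ring size and does not involve the double bond entering here, so it offers no direct guide. With compound 2 at a limit, compound 3 is expected to read near that same limit, with a wide range. Compound 3 is expected at 40 mg/kg, between 15 mg/kg and 100 mg/kg. The expected step is a number no higher from compound 2 to compound 3 (the limit leaves the size open), no change beyond the scatter.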

Compound 3, minimum effective dose: 10 mg/kg
The estimate for compound 3 lay 4.0-fold (0.60 log units) above the measured number; measured number below the stated range.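

In this assay, one double bond outside aromatic rings, with the heavy atoms of the group unchanged, is enough for an at least 4.0-fold lower number from compound 2 to compound 3 (0.60 log units; beyond the scatter). Compound 2 stands at a limit of the assay and not a number: the limit of > 40 mg/kg in this assay, at which 1 of the 3 values shown sits. The five-membered ring group carrying the double bond also matches the four-membered ring group, with no change at the digits printed from compound 1 to compound 3 (within the scatter).

From the compounds shown here alone, the true size of the step from compound 2 stays open. Also open, going by these compounds, is whether a longer chain or a hydroxyl group on this group would keep the read-out of compound 3.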